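Sulfonamide Series Held at the Cytotoxicity Limit

The compounds below may be only part of what the source reports. "The series", "measured", "known", "first", "only" and "open" are said of these compounds alone.

Compound 2 `Cc1cc(C)c(S(=O)(=O)N2CCC(N3CCC(C(C)C)CC3)CC2)c(C)c1` belongs to a small set examined in an ADME assay on HCT-116 cells (Homo sapiens) for cytotoxicity, read by CellTiter-Glo, with a stated time of 72 h; on this read-out lower numbers stand for stronger inhibition and higher numbers for weaker inhibition. In this assay compound 2 gives only a limit, > 5000 nM. Compound 1 `Cc1cc(C)c(S(=O)(=O)N2CCC(N3CCN(C)CC3)CC2)c(C)c1` likewise gives only a limit, > 5000 nM. Compound 3 `Cc1cc(C)c(S(=O)(=O)N2CCC(N3CCC(C)OC3)CC2)c(C)c1` also gives only a limit, > 5000 nM. All three sit on (the limit of > 5000 nM in this assay, at which 3 of the 3 values shown sit), which is why the steps a step that the two limits leave unreadable from compound 1 to compound 2 and a step that the two limits leave unreadable from compound 2 to compound 3 cannot be sized. Compound 4 `C#CCCC(=O)CC1CCN(C2CCN(S(=O)(=O)c3c(C)cc(C)cc3C)CC2)CC1` differs from compound 2 by ((but-3-yn-1-yl)carbonyl)methyl in place of isopropyl on a saturated ring carbon. Among the measured compounds shown here, none of the measured steps carries a readable size, so no shift beyond the scatter in either direction can be foreseen, and the limit reading for compound 2 points to compound 4 remaining weak as well. Compound 4 is expected at 8000 nM, within 2500 nM to 25000 nM. This would mean an expected step that the limit leaves unreadable from compound 2 to compound 4.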

Compound 4, half-maximal inhibitory concentration: > 5000 nM
Compound 4 gave a limit, no number; the forecaster's own chance of this, stated with the estimate: 75%; the middle value does not contradict the limit.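

The step from compound 2 to compound 4 cannot be read, since both give only a limit: the limit of > 5000 nM in this assay, at which 4 of the 4 values shown sit. The compounds shown leave open how far past that limit each lies, and whether any group at this place would give a measurable value.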